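The source may report more compounds than this note shows. Statements on the series, on what has been measured and on what is new or still open speak of the compounds shown alone.

In a functional assay on ECa-109 cells (Homo sapiens) for cytotoxicity, read by MTT assay, with a stated time of 72 h (a higher number here means a weaker inhibitor, a lower number a stronger inhibitor), compound 1 (`CC(C)=C1C(=O)N(c2ccc(Cl)cc2)N(c2ccc(Cl)cc2)C1=O`) gives 42100 nM as a measured number. Compound 2 (`CN(C)c1ccc(C=C2C(=O)N(c3ccc(Cl)cc3)N(c3ccc(Cl)cc3)C2=O)cc1`) stands at > 128000 nM which is a limit of the assay and not a number. Among the compounds with values here, the series therefore offers one measured value and one limit, and no measured step between compounds that differ in one place.

Compound 3 (`COc1cccc(C=C2C(=O)N(c3ccc(Cl)cc3)N(c3ccc(Cl)cc3)C2=O)c1O`) keeps the shared core of compound 2, and the change is 2-hydroxy-3-methoxyphenyl in place of 4-(dimethylamino)phenyl on a double-bonded chain carbon bound to a double-bonded ring carbon which in words is 2-hydroxy-3-methoxyphenyl in place of 4-(dimethylamino)phenyl on a double-bonded chain carbon bound to a double-bonded ring carbon.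

Within the data shown here, with no measured step to lean on, the expectation is anchored on compound 1 at 42100 nM as the only number. The expected move is an at least 2.8-fold lower number from compound 2 to compound 3 (0.45 log units; beyond the scatter) toward a stronger inhibitor, and it is a modest expectation that may not go far beyond the scatter. Another limit remains possible. Estimated in this assay for compound 3 is 45000 nM with 14000 nM to 128000 nM as the expected range.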

Compound 3, half-maximal inhibitory concentration: 39000 nM
Beside the measured number, compound 3's estimate is 1.2-fold (0.06 log units) above it, and the stated range covers the measured number.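

In this assay, 2-hydroxy-3-methoxyphenyl in place of 4-(dimethylamino)phenyl on a double-bonded chain carbon bound to a double-bonded ring carbon gives an at least 3.2-fold lower number from compound 2 to compound 3 (0.51 log units; beyond the scatter). Within the data shown here, this is the first readable step between compounds that differ in one place, and it shows that the aromatic group at this place can move the read-out beyond the scatter. The full size of the step stays undefined, as compound 2 stands at a limit of the assay and not a number: the limit of > 128000 nM in this assay, at which 1 of the 3 values shown sits.

The change removes the dimethylamino group and brings in the hydroxy and methoxy groups together, so the compounds shown do not separate the contribution of each, and a plain phenyl, a 2-hydroxyphenyl or a 3-methoxyphenyl at this place would be needed to do so. Also open, as far as these compounds go, is how far the read-out moves with other groups on this ring, such as a carboxylic acid or a primary amine, or with a longer chain in place of the ring.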